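Bridged bicyclic amine in place of cyclohexyl on quinoline core

The source may report more compounds than this note shows. Statements on the series, on what has been measured and on what is new or still open speak of the compounds shown alone.

Compound 1 `COc1ccc(Cl)cc1C(=O)NCCC1CCN(S(=O)(=O)NC(=O)NC2CCCCC2)CC1` carries a cyclohexyl group on the urea nitrogen. In a functional assay on the whole organism (blood) with Rattus norvegicus as the target, with stated times of 24 h and 1 h, at a dose of 5 mg/kg by the intraperitoneal route (a higher number here means a stronger effect of the compound at the dose given, a lower number a weaker effect), compound 1 gives 25%. Compound 2 `COc1ccc(Cl)cc1C(=O)NCCC1CCN(S(=O)(=O)NC(=O)NC[C@@H]2C[C@@H]3C=C[C@@H]2C3)CC1` differs by a group of 8 heavy atoms (8 carbon; 2 five-membered non-aromatic rings of carbon only) in place of a group of 6 heavy atoms (6 carbon; one six-membered non-aromatic ring of carbon only), on an amide-type nitrogen, and in this assay compound 2 gives 37%, so that a number 12 percentage points higher from compound 1 to compound 2 (beyond the scatter). Compound 3 `COc1ccc2nccc(C(=O)NCCC3CCN(S(=O)(=O)NC(=O)NC4CCCCC4)CC3)c2c1` keeps the cyclohexyl group but differs from compound 1 by 6-methoxyquinolin-4-yl in place of 5-chloro-2-methoxyphenyl on a carbonyl carbon; in this assay compound 3 gives 15%, with a number 10 percentage points lower from compound 1 to compound 3 (within the scatter).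

Compound 4 `COc1ccc2nccc(C(=O)NCCC3CCN(S(=O)(=O)NC(=O)NC[C@@H]4C[C@@H]5C=C[C@@H]4C5)CC3)c2c1` has not been measured. It differs from compound 3 by a group of 8 heavy atoms (8 carbon; 2 five-membered non-aromatic rings of carbon only) in place of a group of 6 heavy atoms (6 carbon; one six-membered non-aromatic ring of carbon only), on an amide-type nitrogen, the same change that separates compound 2 from compound 1, made at the same place in both pairs. Within the data shown here, with only one earlier instance of this change, the expectation leans on that single step. Compound 4 is expected to show a step of a number 12 percentage points higher from compound 3 to compound 4 (beyond the scatter) in this assay. This rests on the step of a number 12 percentage points higher from compound 1 to compound 2 (beyond the scatter) and on compound 3 giving 15%. Compound 4 is therefore estimated at 27%. The estimate for compound 4 should plausibly fall between 12% and 42%.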

Compound 4, a percentage reported as activity, at one dose (the size of the read-out at that dose, not a potency): 10%
Compound 4: middle estimate off by 17 percentage points, on the high side; measured number below the stated range.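

On the core of compound 3, the group of 8 carbon atoms in place of cyclohexyl gave a number 5 percentage points lower from compound 3 to compound 4 (within the scatter) in this assay, so the gain seen on the core of compound 1 did not carry over: the same change on two cores in this assay, a number 12 percentage points higher (beyond the scatter) from compound 1 to compound 2 and a number 5 percentage points lower (within the scatter) from compound 3 to compound 4, 17 percentage points apart, beyond the scatter of two such steps. Read the other way, 6-methoxyquinolin-4-yl in place of 5-chloro-2-methoxyphenyl gave a number 27 percentage points lower from compound 2 to compound 4 (beyond the scatter), and this change too depended on what else the compound carried: the same change on two cores in this assay, a number 10 percentage points lower (within the scatter) from compound 1 to compound 3 and a number 27 percentage points lower (beyond the scatter) from compound 2 to compound 4, 17 percentage points apart, beyond the scatter of two such steps. The two changes therefore did not add up independently across these compounds, but the result rests on a single set of four compounds at one dose, and it shows neither why they depend on each other nor how potency differs.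

The compounds shown leave open whether the same dependence would appear with other groups on the amide-type nitrogen, such as a phenyl ring or a straight butyl chain. They also leave open how the compounds would compare at other doses in this assay.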